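Amide substituent variation at the pyrrole carbonyl

A few compounds are considered here, and "the series" means these few. Any claim that something is new, unique, unknown or untested is made for them only; others in the source may bear on it.

Two compounds of the series have numbers in a functional assay on KARPAS-299 cells (Homo sapiens) for antiproliferative activity, read by MTT assay, with a stated time of 4 h; a lower number here means a stronger inhibitor, a higher number a weaker inhibitor. Compound 1 `COc1cc(-n2cccc2C(=O)N2CCC(C)CC2)ccc1Nc1ncc(Cl)c(Nc2ccccc2NS(C)(=O)=O)n1` gives 1370 nM in this assay. Compound 2 `COc1cc(-n2cccc2C(=O)N(C)C)ccc1Nc1ncc(Cl)c(Nc2ccccc2NS(C)(=O)=O)n1` gives 780 nM in this assay. For the measured compounds named here, the one step that joins them, a 1.8-fold lower number from compound 1 to compound 2 (0.24 log units; within the scatter), stays within the scatter, so compound 2 holds the lower of the two numbers without a difference that can be trusted.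

Compound 3 `CCN(CC)C(=O)c1cccn1-c1ccc(Nc2ncc(Cl)c(Nc3ccccc3NS(C)(=O)=O)n2)c(OC)c1` is not yet measured. It differs from compound 2 by diethylamino in place of dimethylamino on a carbonyl carbon. Going by the values given here, the only measured step that bears on this position is the one from compound 1 to compound 2, which exchanged a larger cyclic amine for the dimethylamino group and stayed within the scatter. Going from dimethylamino to diethylamino is a smaller change on the same carbonyl carbon, and nothing measured points in either direction. The expectation is therefore no movement beyond the scatter; the step from compound 2 to compound 3 is estimated at a 1.0-fold higher number from compound 2 to compound 3 (0.01 log units; within the scatter). Compound 3 is expected to give about 800 nM in this assay, with a range from 350 nM to 1800 nM.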

Compound 3, half-maximal inhibitory concentration: 105 nM
The estimate for compound 3 lay 7.6-fold (0.88 log units) above the measured number; measured number outside the range, below it.
By their numbers in this assay, from the lowest: compound 3; then compounds 2 and 1 (each within the scatter of the next).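

The amine on this carbonyl carbon can move the number in this assay: a 7.4-fold lower number from compound 2 to compound 3 (0.87 log units; beyond the scatter), whereas the earlier step from the 4-methylpiperidin-1-yl amide to the dimethylamino amide stayed within the scatter. Diethylamino also stands clear of 4-methylpiperidin-1-yl, with a 13-fold lower number from compound 1 to compound 3 (1.12 log units; beyond the scatter), so compound 3 is separated from both other compounds, and the order does not follow group size: diethylamino is larger than dimethylamino and smaller than 4-methylpiperidin-1-yl, yet compound 3 holds the lowest number of the three. Nothing available gives a reason for this drop.

Going by these compounds, it remains open how narrow this preference is: an unsymmetrical N-ethyl-N-methylamino group, a longer chain such as di-n-propylamino, or a small ring such as pyrrolidin-1-yl would show whether the gain belongs to diethylamino alone or extends to neighbouring amines. A further open point is whether the same amine change would hold on other versions of the shared core, since all three compounds carry the same remainder.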